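The source may report more compounds than this note shows. Statements on the series, on what has been measured and on what is new or still open speak of the compounds shown alone.

Measured compounds:
compound 1, `Cc1nc(C(=O)Nc2ccc(Cl)c(-c3nnc4c(Cl)cccn34)c2)cs1`
compound 2, `O=C(Nc1ccc(Cl)c(-c2nnc3c(Cl)cccn23)c1)c1ccccc1Cl`
compound 3, `O=C(Nc1ccc(Cl)c(-c2nnc3c(Cl)cccn23)c1)c1ccon1`

In a functional assay on AN3-CA cells (Homo sapiens) for antiproliferative activity, read by MTT assay, with a stated time of 72 h (on this read-out lower numbers stand for stronger inhibition and higher numbers for weaker inhibition), compound 1 returns only a limit of the assay, > 100000 nM, not a number. Compound 2 likewise returns only a limit in this assay, > 100000 nM. Compound 3 also returns only a limit in this assay, > 100000 nM. Compound 3 therefore stands at the limit of > 100000 nM in this assay, at which 3 of the 3 values shown sit; no measured value in the series separates it from the others.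

The three steps among the measured compounds, a step that the two limits leave unreadable from compound 1 to compound 2, a step that the two limits leave unreadable from compound 1 to compound 3 and a step that the two limits leave unreadable from compound 2 to compound 3, cannot be sized, since each runs between two limits. Exchanging the group on the carbonyl carbon among a 2-methyl-1,3-thiazol-4-yl, a 2-chlorophenyl and a 1,2-oxazol-3-yl has so far left every compound beyond the reach of the assay.

Compound 4, `CS(=O)(=O)c1cccc(C(=O)Nc2ccc(Cl)c(-c3nnc4c(Cl)cccn34)c2)c1`, has not yet been measured in this assay. It differs from compound 3 as follows: 3-(methylsulfonyl)phenyl in place of 1,2-oxazol-3-yl on a carbonyl carbon. Among the measured compounds shown here, the same carbonyl carbon has now carried three groups without a readable number, so no step of measurable size is expected in this assay for a number no higher from compound 3 to compound 4 (the limit leaves the size open). Compound 4 is expected to give 100000 nM, within a range of 30000 nM to 300000 nM, most probably again as a limit rather than a number.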

Compound 4, half-maximal inhibitory concentration: > 100000 nM
Compound 4 gave a limit, no number; the forecaster's own chance of this, stated with the estimate: 80%; the middle value lies on the limit itself.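

Compound 4 gives > 100000 nM in this assay, a limit and not a number. The steps to it from compound 1, compound 2 and compound 3 therefore cannot be read, since each runs between two limits. The compounds shown leave open whether any group on this carbonyl carbon gives a measurable number: the limit of > 100000 nM in this assay, at which 4 of the 4 values shown sit.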